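This account rests on a few compounds, and the source may have more. Where it says the series, first, only, none or still open, it means among the compounds named here.

Compound 1 `COc1cccc(CNC(C)=O)c1`: 57000 nM
Compound 2 `CCC(=O)NCc1cccc(OC)c1`: 22000 nM
Compound 3 `CCC(=O)NCCCc1ccc(OC)cc1`: 2900 nM

In an assay for binding affinity to melatonin receptor (Gallus gallus) (on this read-out lower numbers stand for stronger inhibition and higher numbers for weaker inhibition), compound 1 gives 57000 nM. Compound 2 differs from it by methyl in place of hydrogen on a saturated chain carbon bound to a carbonyl carbon, and this brings a 2.6-fold lower number from compound 1 to compound 2 (0.41 log units; beyond the scatter). Compound 3 reaches 2900 nM, the lowest of the three numbers; how its core differs from the core of compound 1 is not broken down here.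

Compound 4 `CCCC(=O)NCCCc1ccc(OC)cc1` is not yet measured. It differs from compound 3 by methyl in place of hydrogen on a saturated chain carbon, two bonds along the chain from a carbonyl carbon. Going by the values given here, this is the same kind of change as the one from compound 1 to compound 2, though not at the same place: there the methyl entered on a saturated chain carbon bound to a carbonyl carbon, here it enters on a saturated chain carbon two bonds along the chain from a carbonyl carbon. Because the earlier step gave a 2.6-fold lower number from compound 1 to compound 2 (0.41 log units; beyond the scatter), a modest gain of similar or slightly smaller size is expected here, since compound 3 already stands lower than compound 2. Compound 4 is therefore expected to show a 1.8-fold lower number from compound 3 to compound 4 (0.26 log units; within the scatter), giving an estimated 1600 nM, likely between 600 nM and 4000 nM.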

Compound 4, inhibition constant: 860 nM
Estimate against measurement, compound 4: 1.9-fold (0.27 log units) above; the measured number falls inside the stated range.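

Methyl in place of hydrogen on a saturated chain carbon, two bonds along the chain from a carbonyl carbon, brings a 3.4-fold lower number from compound 3 to compound 4 (0.53 log units; beyond the scatter) in this assay. Set beside the earlier step, the new one points the same way and differs from it by no more than the scatter: the same change on two cores in this assay, a 2.6-fold lower number (0.41 log units; beyond the scatter) from compound 1 to compound 2 and a 3.4-fold lower number (0.53 log units; beyond the scatter) from compound 3 to compound 4, 1.3-fold (0.11 log units) apart, within the scatter of two such steps. So in these two pairs, a methyl added to the chain on the carbonyl lowers the number by a similar amount on both cores, but two pairs cannot show that this holds on other cores, and the methyl enters at a different place in each pair, so core and place are not separated.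

Still open, on these data alone, is whether the number keeps falling with a longer chain on the carbonyl, or whether a cyclopropyl group or a hydroxyl group at the end of that chain would act like the methyl. As far as these compounds go, compound 2 and compound 3 differ in more than one place, so the part played by each of those differences also remains unknown.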